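Lengthening the hydroxycarbamoyl chain: from compound 2 to compound 3

The source may hold more compounds than are shown below. What is called first, only, known or untested is meant among the compounds shown, and "the series" means these compounds.

Two chain lengths on the shared core have been measured so far in a functional assay on B16 cells (Mus musculus) for inhibition, read by MTT assay, with a stated time of 48 h (on this read-out higher numbers stand for weaker inhibition and lower numbers for stronger inhibition), and no others. Compound 1 `O=C(CCCCOC(=O)c1ccc2c(c1)no[n+]2[O-])NO` gives 24000 nM there and compound 2 `O=C(CCCCCOC(=O)c1ccc2c(c1)no[n+]2[O-])NO` gives 30300 nM on the same scale. Among the compounds with values here, compound 2 thus stands within the scatter of compound 1, its only measured neighbour, and the two cannot be ranked.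

Compound 3 `O=C(CCCCCCCOC(=O)c1ccc2c(c1)no[n+]2[O-])NO` differs from compound 2 by 2-(hydroxycarbamoyl)ethyl in place of hydroxycarbamoyl on a saturated chain carbon, five bonds along the chain from an oxygen next to a carbonyl group and so carries 2-(hydroxycarbamoyl)ethyl in place of hydroxycarbamoyl on a saturated chain carbon, five bonds along the chain from an oxygen next to a carbonyl group.

Within the data shown here, the only measured step of this kind is a 1.3-fold higher number from compound 1 to compound 2 (0.10 log units; within the scatter) and it is the sole guide, although no measured compound carries a chain this long. From the compounds shown here alone, on that basis no step beyond the scatter is expected in this assay and the direction stays open. The estimated step is a 1.0-fold lower number from compound 2 to compound 3 (0.00 log units; within the scatter) and it rests on a single comparison. For compound 3 the estimated value is 30000 nM within an expected range from 12000 nM to 70000 nM overall.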

Compound 3, half-maximal inhibitory concentration: 7990 nM
Beside the measured number, compound 3's estimate is 3.8-fold (0.57 log units) above it, outside the stated range (below it).
By their numbers in this assay, from the lowest: compound 3; then compounds 1 and 2 (each within the scatter of the next).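

In this assay, within the data shown here, the position responds to chain extension after all: 2-(hydroxycarbamoyl)ethyl in place of hydroxycarbamoyl gives a 3.8-fold lower number from compound 2 to compound 3 (0.58 log units; beyond the scatter), the first step to lie beyond the scatter. The response is uneven across the three chain lengths, since a 1.3-fold higher number from compound 1 to compound 2 (0.10 log units; within the scatter) is a step that cannot be told from the scatter, whereas 3-(hydroxycarbamoyl)propyl in place of hydroxycarbamoyl gives a 3.0-fold lower number from compound 1 to compound 3 (0.48 log units; beyond the scatter), which makes compound 3 the most potent of the three on this read-out, with modest steps to both others. No measured evidence at hand accounts for this difference between the steps.

Three chain lengths cannot show whether a chain longer than that of compound 3 would bring the number down further, level off or raise it again, so no optimum can be placed on this series. Also open, from the compounds shown here alone, is whether the hydroxycarbamoyl end is needed for the step, which a carboxylic acid or a primary amide at the end of the chain of compound 3 would test.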